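The compounds below may be only part of what the source reports. "The series", "measured", "known", "first", "only" and "open" are said of these compounds alone.

Compound 1 `COc1ccc(/C=C/c2nc(NCCN(C(C)C)C(C)C)c3ccccc3n2)cc1OC` and compound 2 `COc1ccc(/C=C/c2nc(NCCN3CCCCC3)c3ccccc3n2)cc1OC` share one core and differ in a single place: piperidin-1-yl in place of diisopropylamino on a saturated chain carbon, two bonds along the chain from a nitrogen on an aromatic ring. In a functional assay on MGC-803 cells (Homo sapiens) for cytotoxicity, read by MTT assay, with stated times of 48 h and 4 h (a lower number here means a stronger inhibitor, a higher number a weaker inhibitor), compound 1 gives 15500 nM, while compound 2 gives 33200 nM. Compound 3 `CC(C)N(CCNc1nc(/C=C/c2ccc([N+](=O)[O-])cc2)nc2ccc(Cl)cc12)C(C)C` carries a different core; the difference between the two cores is not broken down here. In this assay compound 3 gives 17300 nM. Compound 4 `O=[N+]([O-])c1ccc(/C=C/c2nc(NCCN3CCCCC3)c3cc(Cl)ccc3n2)cc1` is reached from compound 3 by the same change as before, at the same place: piperidin-1-yl in place of diisopropylamino on a saturated chain carbon, two bonds along the chain from a nitrogen on an aromatic ring. Among the measured compounds shown here, for compound 4 a step of a 2.0-fold higher number from compound 3 to compound 4 (0.31 log units; beyond the scatter) is expected, because the only earlier example of this change gave a 2.1-fold higher number from compound 1 to compound 2 (0.33 log units; beyond the scatter), and it is uncertain whether a single example carries over to a different core. For compound 4 the expected value in this assay is 35000 nM, with a likely range from 17000 nM to 75000 nM.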

Compound 4, half-maximal inhibitory concentration: 20000 nM
For compound 4 the middle estimate is 1.8-fold (0.24 log units) above the measured one, and the stated range covers the measured number.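

In this assay, the core of compound 3 gives a 1.2-fold higher number from compound 3 to compound 4 (0.06 log units; within the scatter), so on this core the swap of diisopropylamino for piperidin-1-yl produces no change that can be told apart from ordinary measurement noise. Set beside the first example, the two steps still cannot be told apart: the same change on two cores in this assay, a 2.1-fold higher number (0.33 log units; beyond the scatter) from compound 1 to compound 2 and a 1.2-fold higher number (0.06 log units; within the scatter) from compound 3 to compound 4, 1.9-fold (0.27 log units) apart, within the scatter of two such steps. This means the data show no clear disagreement between the two cores, but two pairs do not prove that the step has the same size on both, or that it would hold on a third core.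

The compounds shown leave open how a different amine, such as morpholin-4-yl or dimethylamino, would behave at this place. They also leave open what a longer chain carrying the same amines would do.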